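A few compounds are considered here, and "the series" means these few. Any claim that something is new, unique, unknown or untested is made for them only; others in the source may bear on it.

Compound 1 `COC(=O)N1CCC(Oc2ncnc3c2CCN3c2ccc(S(C)(=O)=O)cc2F)CC1` carries a methoxycarbonyl on an amine nitrogen in a ring. Within the data shown here, in a functional assay on CHO-K1 cells for agonist activity at Glucose-dependent insulinotropic receptor (Homo sapiens), read by a luciferase reporter, with a stated time of 5 h (a higher number here means that more compound is needed for the effect, a lower number that less compound is needed), compound 1 gives 316 nM, the highest of the three numbers so far. Compound 2 `CC(C)SC(=O)N1CCC(Oc2ncnc3c2CCN3c2ccc(S(C)(=O)=O)cc2F)CC1` gives 10 nM, and compound 3 `CS(=O)(=O)c1ccc(N2CCc3c(OC4CCN(C(=S)Sc5ccccc5)CC4)ncnc32)c(F)c1` gives 12.6 nM. Among the measured compounds shown here, two steps bear on the change in hand: a 32-fold lower number from compound 1 to compound 2 (1.50 log units; beyond the scatter) and a 25-fold lower number from compound 1 to compound 3 (1.40 log units; beyond the scatter), both replacing the methoxycarbonyl on that nitrogen with a larger group. Compound 4 `CC(C)c1noc(N2CCC(Oc3ncnc4c3CCN4c3ccc(S(C)(=O)=O)cc3F)CC2)n1` makes a change of the same kind: 3-isopropyl-1,2,4-oxadiazol-5-yl in place of methoxycarbonyl on an amine nitrogen in a ring. A large downward step is therefore expected, an 11-fold lower number from compound 1 to compound 4 (1.02 log units; beyond the scatter), though a five-membered aromatic ring has not been measured at this position, so the step is expected somewhat smaller than those seen. Compound 4 is estimated at 30 nM, with a range of 8 nM to 120 nM.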

Compound 4, half-maximal effective concentration: 79.4 nM
For compound 4 the middle estimate is 2.6-fold (0.42 log units) below the measured one; low and high end bracket the measured number.
By their numbers in this assay, from the lowest: compounds 2 and 3 (each within the scatter of the next); then compound 4; then compound 1.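

Compound 4 shows that the number in this assay can fall without a sulfur-bearing group on this amine nitrogen in a ring, as 3-isopropyl-1,2,4-oxadiazol-5-yl still gives a 4.0-fold lower number from compound 1 to compound 4 (0.60 log units; beyond the scatter) in place of methoxycarbonyl. The fall is only partial, with a 7.9-fold higher number from compound 2 to compound 4 (0.90 log units; beyond the scatter) and a 6.3-fold higher number from compound 3 to compound 4 (0.80 log units; beyond the scatter), so the group chosen here sets how far the number drops. Nothing shown offers a reason for this gap. As far as these compounds go, it remains open whether a smaller alkyl in place of the isopropyl on the oxadiazole, or a pyrimidine in place of the oxadiazole, would close it.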